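Configuration change at a saturated ring carbon

The source may report more compounds than this note shows. Statements on the series, on what has been measured and on what is new or still open speak of the compounds shown alone.

Among the measured compounds shown here, in a functional assay on MDA-MB-231 cells (Homo sapiens) for inhibition, read by MTT assay, with a stated time of 72 h (a higher number here means a weaker inhibitor, a lower number a stronger inhibitor), compound 1 (`CC1=NN(c2ccccc2)C(=O)[C@@]12C(=O)C=CC[C@H]2c1ccc(C)cc1`) gives 8300 nM and compound 2 (`CC1=NN(c2ccccc2)C(=O)[C@@]12C(=O)C=CC[C@@H]2c1ccc(C)cc1`) gives 7420 nM, so compound 2 stands within the scatter of the only other number. Compound 3 (`CC1=NN(c2ccccc2)C(=O)[C@]12C(=O)C=CC[C@@H]2c1ccc(C)cc1`) departs from compound 2 by the two compounds have the same atoms and bonds and differ only in configuration as drawn: 1 of 2 stereo elements differ; a stereocentre at a saturated ring carbon is drawn R in compound 2 and S in compound 3. For the measured compounds named here, the sole measured step bearing on this is a 1.1-fold lower number from compound 1 to compound 2 (0.05 log units; within the scatter), which reflects (the fact that compounds 1 and 2 differ only in the configuration as drawn). This single small step is thin evidence, but it gives no reason to expect a change beyond the scatter in this assay. The expected step is a 1.0-fold higher number from compound 2 to compound 3 (0.01 log units; within the scatter). Compound 3 is estimated at 7600 nM, with an expected range of 3500 nM to 16000 nM.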

Compound 3, half-maximal inhibitory concentration: 6240 nM
The estimate for compound 3 lay 1.2-fold (0.09 log units) above the measured number; measured number inside the range.
By their numbers in this assay, from the lowest: compounds 3, 2 and 1 (each within the scatter of the next).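

In this assay, inverting the other stereocentre also leaves the number within the scatter, with a 1.2-fold lower number from compound 2 to compound 3 (0.08 log units; within the scatter). Inverting both stereocentres to give the mirror image does the same, with a 1.3-fold lower number from compound 1 to compound 3 (0.12 log units; within the scatter). Across these three stereoisomers, neither a single inversion nor full inversion separates the compounds in this assay.

From the compounds shown here alone, the remaining arrangement of the two stereocentres stays open. So does whether an amine or a carboxylic acid on the shared core would bring out a difference between stereoisomers.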